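The source may report more compounds than this note shows. Statements on the series, on what has been measured and on what is new or still open speak of the compounds shown alone.

Compound 1 `c1ccc(-c2cc3nn(-c4ccccc4)cc3cn2)cc1` gives 3400 nM in a functional assay on K562 cells (Homo sapiens) for inhibition, read by fluorescence, with a stated time of 72 h (on this read-out lower numbers stand for stronger inhibition of growth and higher numbers for weaker inhibition of growth), the lowest of the two numbers measured there. Compound 3 `Cc1nc(-c2ccccc2)cc2nn(-c3ccccc3)cc12` gives 6300 nM in this assay, a step of a 1.9-fold higher number from compound 1 to compound 3 (0.27 log units; within the scatter). Compound 2 `Cn1cc2cnc(-c3ccccc3)cc2n1` reaches only a limit, > 100000 nM in this assay. That limit is the limit of > 100000 nM in this assay, at which 1 of the 3 values shown sits, and the step of an at least 29-fold higher number from compound 1 to compound 2 (1.46 log units; beyond the scatter) is large. Compound 4 `c1ccc(-n2cc3cnc(C4CC4)cc3n2)cc1` differs from compound 1 by cyclopropyl in place of phenyl on an aromatic carbon. For the measured compounds named here, no measured step removes phenyl from an aromatic carbon; the removal of phenyl from the aromatic nitrogen in an at least 29-fold higher number from compound 1 to compound 2 (1.46 log units; beyond the scatter) cost much, while the carbon-side change in a 1.9-fold higher number from compound 1 to compound 3 (0.27 log units; within the scatter) stayed within the scatter. A weakening of moderate size is therefore expected. Compound 4 is estimated at 15000 nM, between 4000 nM and 60000 nM, an expected step of a 4.4-fold higher number from compound 1 to compound 4 (0.64 log units; beyond the scatter).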

Compound 4, concentration for 50% growth inhibition: 60500 nM
Beside the measured number, compound 4's estimate is 4.0-fold (0.61 log units) below it, and the stated range ends below it.
By their numbers in this assay, from the lowest: compounds 1 and 3 (each within the scatter of the next); then compound 4. At a limit, above all of these: compound 2.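

Cyclopropyl in place of phenyl on this aromatic carbon, next to the ring nitrogen, gives an 18-fold higher number from compound 1 to compound 4 (1.25 log units; beyond the scatter), so the phenyl here matters in this assay. Until now only the phenyl on the aromatic nitrogen had shown a large step, while the methyl change on another aromatic carbon, a 1.9-fold higher number from compound 1 to compound 3 (0.27 log units; within the scatter), stayed within the scatter. Compound 1 thus depends on both of its phenyl groups, not on the nitrogen-side one alone. Nothing shown here accounts for the size of this step. From the compounds shown here alone, whether a pyridyl, a methoxy or an amine at this carbon would match phenyl stays open.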